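Swapping a dichlorophenoxy group for a fluorophenylsulfanyl group

This account rests on a few compounds, and the source may have more. Where it says the series, first, only, none or still open, it means among the compounds named here.

Of the compounds shown here, three that share one core have been tested in a functional assay on EKVX cells (Homo sapiens) for inhibition, read by sulforhodamine B assay, with a stated time of 48 h; a higher number here means a weaker inhibitor of growth, a lower number a stronger inhibitor of growth. Compound 1, with structure `Nc1cc(N)c2nc(-c3ccccc3)c(Oc3ccc(Cl)c(Cl)c3)nc2c1`, gives 8320 nM in this assay. Compound 2, with structure `Nc1cc(N)c2nc(-c3ccccc3)c(NCc3ccc(Cl)c(Cl)c3)nc2c1`, gives 38900 nM, and compound 3, with structure `CCOC(=O)[C@H](CCC(=O)O)NC(=O)c1ccc(Sc2nc3cc(N)cc(N)c3nc2-c2ccccc2)cc1`, gives 60300 nM. Among the three, compound 1 has the lowest number, and both gaps to the other two lie beyond the scatter of repeated measurements, so compound 1 is the strongest inhibitor of growth in this set.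

Compound 4, with structure `Nc1cc(N)c2nc(-c3ccccc3)c(Sc3ccc(F)cc3)nc2c1`, has not yet been measured. It differs from compound 1 in one place: (4-fluorophenyl)sulfanyl in place of 3,4-dichlorophenoxy on an aromatic carbon. The group that leaves and the group that enters are of similar size, each built on one six-membered aromatic ring of carbon only, each with no hydrogen-bond donor and one hydrogen-bond acceptor. For the measured compounds named here, no pair of measured compounds differs in exactly one place, so no measured step guides this change directly. The step that the estimate below means, a 1.3-fold higher number from compound 1 to compound 4 (0.12 log units; within the scatter), is expected to be small, within the scatter, with a slight lean toward a higher number. For compound 4 the estimated value in this assay is 11000 nM, expected to fall between 3500 nM and 40000 nM.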

Compound 4, concentration for total growth inhibition: 41700 nM
Compound 4: the middle estimate sits 3.8-fold (0.58 log units) below what was measured; the measured number lies above the stated range.
By their numbers in this assay, from the lowest: compound 1; then compounds 2, 4 and 3 (each within the scatter of the next).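

In this assay, replacing 3,4-dichlorophenoxy with (4-fluorophenyl)sulfanyl gives a 5.0-fold higher number from compound 1 to compound 4 (0.70 log units; beyond the scatter) and so shows that this position on the shared core does not treat the two groups alike. This holds even though each group is built on one six-membered aromatic ring of carbon only and each has the same counts of hydrogen-bond donors and acceptors, so similar size and matching counts are not enough here to keep the number in place. No measured finding is available to explain this step.

The swap changes the linking atom from oxygen to sulfur and also replaces the two chlorines with one fluorine, so this single pair cannot show which of these changes accounts for the step. Two groups not among the compounds shown would separate them: 4-fluorophenoxy keeps the oxygen link with the new ring, and (3,4-dichlorophenyl)sulfanyl keeps the sulfur link with the old ring.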